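Fluoro for hydroxy on a lactone-free comparison of two values

A few compounds are considered here, and "the series" means these few. Any claim that something is new, unique, unknown or untested is made for them only; others in the source may bear on it.

Measured so far in a functional assay on HL-60 cells (Homo sapiens) for cytotoxicity, read by WST assay, with a stated time of 48 h; on this read-out lower numbers stand for an effect already at smaller amounts and higher numbers for an effect only at larger amounts of compound:
Compound 1 `Cc1ccc(C[C@H]2C(=O)OC[C@@H]2Cc2ccccc2)cc1C`: 35000 nM
Compound 2 `O=C1OC[C@H](Cc2ccccc2O)[C@H]1Cc1ccc(Cl)c(Cl)c1`: 33000 nM

Compound 2, at 33000 nM, stands level with compound 1, at 35000 nM: the two numbers lie within the usual scatter of each other, so neither can be ranked ahead. Compound 3 `O=C1OC[C@H](Cc2ccccc2F)[C@H]1Cc1ccc(Cl)c(Cl)c1` follows from compound 2 by one exchange, fluoro in place of hydroxy on an aromatic carbon, ortho to a large group, which turns 2-hydroxyphenyl into 2-fluorophenyl (fluoro in place of hydroxy on an aromatic carbon). For the measured compounds named here, no measured pair shows what such an exchange does in this assay, so no direction can be argued from the data. The expected change a 1.1-fold lower number from compound 2 to compound 3 (0.04 log units; within the scatter) is therefore none beyond the scatter. For compound 3 the estimated value is 30000 nM, with an expected range from 12000 nM to 70000 nM.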

Compound 3, half-maximal effective concentration: 28000 nM
For compound 3 the middle estimate is 1.1-fold (0.03 log units) above the measured one; measured number inside the range.
By their numbers in this assay, from the lowest: compounds 3, 2 and 1 (each within the scatter of the next).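

In this assay, for the compounds shown here, the exchange of 2-hydroxyphenyl for 2-fluorophenyl gives a 1.2-fold lower number from compound 2 to compound 3 (0.07 log units; within the scatter), so the first measured pair at this place, on an aromatic carbon ortho to a large group, shows no change beyond the scatter. Hydroxy, which counts one hydrogen-bond donor and one acceptor, can therefore give way to fluoro, which counts neither, without the number moving beyond the scatter. Nothing measured on these compounds bears on the reason for this result.

The compounds shown leave open whether another group at this place, such as an amine, a carboxylic acid or methoxy, would move the number beyond the scatter. They also leave open whether the same exchange would read alike on a compound with a much lower number.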